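Imidazole for triazole on a shared aryl-imidazoline scaffold

The source may hold more compounds than are shown below. What is called first, only, known or untested is meant among the compounds shown, and "the series" means these compounds.

Of the compounds shown here, three that share one core have been measured in a functional assay with Alpha-1A adrenergic receptor (Homo sapiens) as the target, read by calcium flux; a higher number here means a larger maximal response, a lower number a smaller maximal response. Compound 1 `CCn1ccc(-c2ccccc2NCC2=NCCN2)n1` gives a maximal response of 78% in this assay, compound 3 `CCn1cccc1-c1ccccc1NCC1=NCCN1` gives 93%, and compound 2 `Cc1n[nH]c(-c2ccccc2NCC2=NCCN2)n1` gives 87%. Compound 2 stands with its number among the other two: the gap to compound 3 and the gap to compound 1 both lie within the usual scatter of this measurement, so the three compounds cannot be told apart on these readings.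

Compound 4 `Cn1ccnc1-c1ccccc1NCC1=NCCN1` has not yet been measured in this assay. It differs from compound 2 in one place: 1-methyl-1H-imidazol-2-yl in place of 3-methyl-1H-1,2,4-triazol-5-yl on an aromatic carbon. For the measured compounds named here, no step between two measured compounds of this set involves the same exchange, so nothing measured speaks directly to its effect. Because the three measured compounds, with values of 78% for compound 1, 87% for compound 2 and 93% for compound 3, all sit within the scatter of one another despite carrying different five-membered rings at this position, the expectation is a step from compound 2 to compound 4 of a number 2 percentage points lower from compound 2 to compound 4 (within the scatter), that is none beyond the scatter. On this basis compound 4 is estimated to give 85% in this assay, with a range from 70% to 98%.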

Compound 4, largest response reached (reported as maximal response), in percent of the reference or control that the assay uses: 88%
Beside the measured number, compound 4's estimate is 3 percentage points below it; the measured number falls inside the stated range.
By their numbers in this assay, from the lowest: compounds 1, 2, 4 and 3 (each within the scatter of the next, the first and the last beyond it).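

In this assay, for the compounds shown here, the exchange of 3-methyl-1H-1,2,4-triazol-5-yl for 1-methyl-1H-imidazol-2-yl on this aromatic carbon gives a step of a number 1 percentage points higher from compound 2 to compound 4 (within the scatter), and it is the first step in this set between two compounds that differ in one place only. The entering ring has one hetero atom fewer and no hydrogen-bond donor where the leaving ring has one, yet these differences come with no change in maximal response beyond the scatter, so at this position the maximal response does not depend on that donor or on the third ring nitrogen in this pair. Nothing at hand gives a reason for this result.

Every compound shown carries a five-membered aromatic ring at this position, so it remains open whether a group of another kind there, such as a carboxylic acid, an amine or an open alkyl chain, would keep the maximal response. Also open, on these data alone, is whether the methyl group on the imidazole of compound 4 can give way to a longer chain without a step beyond the scatter.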